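Changing the ring on the sulfonyl sulfur of compound 2

The source may hold more compounds than are shown below. What is called first, only, known or untested is meant among the compounds shown, and "the series" means these compounds.

Of the compounds shown here, three sharing one core have been measured. Compound 1 `COc1ccc(S(=O)(=O)c2cnc3c(F)cccc3c2-c2cccc(F)c2)cc1` gives 3.03 mL/min in an ADME assay on microsomes from liver (Homo sapiens) for metabolic stability, tested at 2.5 uM; on this read-out lower numbers stand for slow clearance and higher numbers for fast clearance. Compound 2 `COc1ccc(S(=O)(=O)c2cnc3c(F)cccc3c2-c2ccc(Cl)cc2)cc1` gives 1.05 mL/min, and compound 3 `COc1ccc(S(=O)(=O)c2cnc3c(F)cccc3c2-c2cccc(OC)c2)cc1` gives 2.87 mL/min. Compound 2 therefore stands lowest of the three: the step of a 2.9-fold lower number from compound 1 to compound 2 (0.46 log units; beyond the scatter) and the step of a 2.7-fold higher number from compound 2 to compound 3 (0.44 log units; beyond the scatter) both lie beyond the scatter, while the step of a 1.1-fold lower number from compound 1 to compound 3 (0.02 log units; within the scatter) lies within it.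

Compound 4 `Cc1ccc(S(=O)(=O)c2cnc3c(F)cccc3c2-c2ccc(Cl)cc2)cc1F` has not yet been measured. It differs from compound 2 in one place: 3-fluoro-4-methylphenyl in place of 4-methoxyphenyl on a sulfonyl sulfur. Among the measured compounds shown here, every measured step, however, concerns the ring on the aromatic carbon, not the ring on the sulfonyl sulfur, so no measured step bears directly on this change. For the measured compounds named here, the only guide is that the single-ring swaps seen here moved the number by modest amounts at most. Compound 4 is therefore estimated at 1.6 mL/min, with a range from 0.6 mL/min to 4.5 mL/min. The step from compound 2 that this estimate means, a 1.5-fold higher number from compound 2 to compound 4 (0.18 log units; within the scatter), is expected to stay near the scatter.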

Compound 4, intrinsic clearance in a liver preparation (reported as CLH), per the amount of preparation that the assay uses: 2.2 mL/min
Compound 4: middle estimate off by 1.4-fold (0.14 log units), on the low side, within the range that was stated.
By their numbers in this assay, from the lowest: compound 2; then compounds 4, 3 and 1 (each within the scatter of the next).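

Among the compounds shown here, the step of a 2.1-fold higher number from compound 2 to compound 4 (0.32 log units; beyond the scatter) is the first measured change to the ring on the sulfonyl sulfur in this assay, and it shows that this position also affects the number. The 4-methoxyphenyl and 3-fluoro-4-methylphenyl groups each hold one six-membered aromatic ring of carbon only and the same number of heavy atoms, yet the step lies beyond the scatter. Compound 2 remains the lowest of the four compounds, with its steps to each of the others beyond the scatter.

No measurement shown here explains why the number rises with this swap. Going by these compounds, it remains open whether the fluoro or the methyl group accounts for the step, and what an amine, a carboxylic acid or a longer chain on this ring would give.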